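Octyl to 3-chlorophenyl on the acyl carbonyl

A few compounds are considered here, and "the series" means these few. Any claim that something is new, unique, unknown or untested is made for them only; others in the source may bear on it.

In a functional assay on NCI-H23 cells (Homo sapiens) for cytotoxicity, read by sulforhodamine B assay, with a stated time of 72 h (a lower number here means a stronger inhibitor of growth, a higher number a weaker inhibitor of growth), compound 1 (`O=C(Nc1cc(C(F)(F)F)cc(C(F)(F)F)c1)C1CCc2ccccc2N1C(=O)c1ccccc1Cl`) gives 2080 nM and compound 2 (`CCCCCCCCC(=O)N1c2ccccc2CCC1C(=O)Nc1cc(C(F)(F)F)cc(C(F)(F)F)c1`) gives 3230 nM. These two values lie within the scatter of each other, so neither compound ranks ahead. Compound 3 (`O=C(Nc1cc(C(F)(F)F)cc(C(F)(F)F)c1)C1CCc2ccccc2N1C(=O)c1cccc(Cl)c1`) has 3-chlorophenyl in place of octyl on a carbonyl carbon, relative to compound 2 (3-chlorophenyl in place of octyl on a carbonyl carbon). The other neighbour of that carbonyl carbon is an amide-type nitrogen in a ring. For the measured compounds named here, one measured step bears on this exchange: a 1.6-fold higher number from compound 1 to compound 2 (0.19 log units; within the scatter), with octyl in place of 2-chlorophenyl, stays within the scatter. Going by the values given here, no measured compound carries 3-chlorophenyl, so this support is indirect. No change beyond the scatter is expected in this assay, and the estimated step is a 1.3-fold lower number from compound 2 to compound 3 (0.13 log units; within the scatter). Compound 3 is expected at 2400 nM, with an estimated range of 900 nM to 6000 nM.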

Compound 3, concentration for 50% growth inhibition: 420 nM
Beside the measured number, compound 3's estimate is 5.7-fold (0.76 log units) above it, and the stated range ends above it.
By their numbers in this assay, from the lowest: compound 3; then compounds 1 and 2 (each within the scatter of the next).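

In this assay, for the compounds shown here, the acyl group on the carbonyl carbon can shift the read-out: 3-chlorophenyl in place of octyl gives a 7.7-fold lower number from compound 2 to compound 3 (0.89 log units; beyond the scatter), whereas the only earlier step stayed within the scatter. An aryl ring alone does not account for this, as compound 1 carries 2-chlorophenyl and lies within the scatter of compound 2, while 3-chlorophenyl in place of 2-chlorophenyl gives a 5.0-fold lower number from compound 1 to compound 3 (0.69 log units; beyond the scatter). No measurement in hand gives a reason for either step.

As far as these compounds go, how an unsubstituted phenyl, a 4-chlorophenyl or a 3-methoxyphenyl group would read on this carbonyl remains open, so the role of the chlorine in 3-chlorophenyl cannot yet be separated from that of the ring. From the compounds shown here alone, whether a shorter chain than octyl would differ from compound 2 also remains open.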